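A few compounds are considered here, and "the series" means these few. Any claim that something is new, unique, unknown or untested is made for them only; others in the source may bear on it.

Measured compounds:
compound 1, `COc1ccc(C2=Cc3ccc(F)cc3C(CC(C)=O)N2c2ccc([N+](=O)[O-])cc2)cc1`: 11200 nM
compound 2, `COc1ccc(C2=Cc3ccc(F)cc3C(CC(C)=O)N2c2ccc(C#N)cc2)cc1`: "not determined" (no result reported)

Within the data shown here, compound 1 carries the only number here; compound 2 gives "not determined" (no result reported) in an ADME assay on TZM cells (Homo sapiens) for cytotoxicity, read by CellTiter-Glo, with a stated time of 48 h (on this read-out higher numbers stand for lower toxicity in this test and lower numbers for higher toxicity in this test), in which compound 1 gives 11200 nM. Compound 3 `COc1ccc(C2=Cc3ccc(F)cc3C(CC(=O)C(C)O)N2c2ccc([N+](=O)[O-])cc2)cc1` differs from compound 1 by 1-hydroxyethyl in place of methyl on a carbonyl carbon. Among the measured compounds shown here, no step between two measured compounds is known, so the expected size of the step rests on the change alone: a step within the usual scatter is expected, if anything towards lower toxicity. For compound 3 the estimated value is 13000 nM, with a range from 5000 nM to 35000 nM. This amounts to an expected step of a 1.2-fold higher number from compound 1 to compound 3 (0.06 log units; within the scatter).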

Compound 3, half-maximal cytotoxic concentration: 10100 nM
Estimate against measurement, compound 3: 1.3-fold (0.11 log units) above; low and high end bracket the measured number.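

In this assay, putting 1-hydroxyethyl in place of methyl on a carbonyl carbon gives a 1.1-fold lower number from compound 1 to compound 3 (0.04 log units; within the scatter). This first measured step shows that, at this position, a larger group carrying a hydroxyl oxygen leaves the two compounds within the usual scatter of each other. Going by these compounds, whether an amine, a carboxylic acid or a longer chain on this carbonyl carbon would also stay within that scatter remains open. This single step also cannot speak for other parts of the shared core. No supporting measurement bears on why this result came out as it did.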